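Sulfonyl-to-sulfanyl swap on a cytotoxicity series

The source may hold more compounds than are shown below. What is called first, only, known or untested is meant among the compounds shown, and "the series" means these compounds.

Measured so far:
compound 1, `CC(O)(CS(=O)(=O)c1ccc(Br)cc1)c1nc(-c2ccc([N+](=O)[O-])c(C(F)(F)F)c2)no1`, > 100000 nM
compound 2, `CC(O)(CSc1ccccc1)c1nc(-c2ccc(Cl)cc2)no1`, 4500 nM

In a functional assay on DU-145 cells (Homo sapiens) for cytotoxicity, read by MTT assay (a lower number here means a stronger inhibitor, a higher number a weaker inhibitor), compound 1 gives > 100000 nM, which is a limit of the assay and not a number (the limit of > 100000 nM in this assay, at which 1 of the 2 values shown sits). Compound 2, which carries a sulfanyl link, gives 4500 nM in this assay. Compound 3, `CC(O)(CSc1ccc(F)cc1)c1nc(-c2ccc([N+](=O)[O-])c(C(F)(F)F)c2)no1`, is not yet measured; it differs from compound 1 by (4-fluorophenyl)sulfanyl in place of (4-bromophenyl)sulfonyl on a saturated chain carbon, two bonds along the chain from an aromatic carbon and an oxygen on a saturated carbon. Within the data shown here, no measured step covers this change, so the expectation rests on compound 2 giving 4500 nM with its sulfanyl link. The step from compound 1 to compound 3 is expected to run toward stronger inhibition, an at least 5.0-fold lower number from compound 1 to compound 3 (0.69 log units; beyond the scatter). Compound 3 is estimated at 20000 nM, between 4000 nM and 100000 nM.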

Compound 3, half-maximal inhibitory concentration: 5100 nM
Estimate against measurement, compound 3: 3.9-fold (0.59 log units) above; low and high end bracket the measured number.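

In this assay the saturated chain carbon proves sensitive to its substituent: (4-fluorophenyl)sulfanyl in place of (4-bromophenyl)sulfonyl gives a large step (an at least 19-fold lower number from compound 1 to compound 3 (1.29 log units; beyond the scatter)) on an otherwise unchanged structure. Compound 1 sits at a limit of the assay, so this step has a lower bound only: the limit of > 100000 nM in this assay, at which 1 of the 3 values shown sits.

The sulfonyl-to-sulfanyl change and the bromine-to-fluorine change travel together in this step, so their separate shares cannot be read. As far as these compounds go, whether a sulfinyl link or an amine link at this position would keep the stronger inhibition remains open.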